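A few compounds are considered here, and "the series" means these few. Any claim that something is new, unique, unknown or untested is made for them only; others in the source may bear on it.

Compound 1 `CNc1ncc2c(-c3ccc(N4CCN(C)CC4)nc3)nn(Cc3cn(Cc4ccccc4)nn3)c2n1`: 2000 nM
Compound 2 `CCN1CCN(c2ccc(-c3nn(Cc4cn(Cc5ccccc5)nn4)c4nc(NC)ncc34)cn2)CC1`: a limit, > 10000 nM

In an assay for inhibition of tyrosine-protein kinase Mer (Homo sapiens), read by 33P incorporation, in the presence of a further agent that is not named here (a higher number here means a weaker inhibitor, a lower number a stronger inhibitor), compound 1 gives 2000 nM. For compound 2 only a limit is recorded in this assay, > 10000 nM, which is the limit of > 10000 nM in this assay, at which 1 of the 2 values shown sits. Among the measured compounds shown here, the single measured step, an at least 5.0-fold higher number from compound 1 to compound 2 (0.69 log units; beyond the scatter), concerns the amine nitrogen in a ring and not the position changed next. Compound 3 `CCN1CCN(c2ccc(-c3nn(CC4CCCC4)c4nc(NC)ncc34)cn2)CC1` carries cyclopentyl in place of 1-benzyl-1H-1,2,3-triazol-4-yl on a saturated chain carbon bound to an aromatic nitrogen. For the measured compounds named here, no measured step bears on this change, so no direction beyond the scatter can be drawn from the two values. Starting from a limit, compound 3 is expected near 10000 nM, range 2500 nM to 40000 nM, a step of a number no higher from compound 2 to compound 3 (the limit leaves the size open) that is estimated with a fair chance of another limit.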

Compound 3, half-maximal inhibitory concentration: 2500 nM
The estimate for compound 3 lay 4.0-fold (0.60 log units) above the measured number; the measured number falls inside the stated range.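

In this assay, the group on the saturated chain carbon bound to an aromatic nitrogen affects the result: an at least 4.0-fold lower number from compound 2 to compound 3 (0.60 log units; beyond the scatter). The 1-benzyl-1H-1,2,3-triazol-4-yl group is therefore not required for a measurable value, as compound 3 carries cyclopentyl, with no aromatic ring in that group. As far as these compounds go, the value for compound 2 is a limit, so the full size of this step stays open: the limit of > 10000 nM in this assay, at which 1 of the 3 values shown sits.

From the compounds shown here alone, whether a smaller ring such as cyclopropyl, or a chain ending in an amine, would give a lower number at this place remains open.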